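The source may report more compounds than this note shows. Statements on the series, on what has been measured and on what is new or still open speak of the compounds shown alone.

Compound 1 `Cc1ncc([N+](=O)[O-])n1CCSc1nnc(-c2ccccc2)o1` is the parent of this small series. In a functional assay on MCF7 cells (Homo sapiens) for cytotoxicity, read by MTT assay, with a stated time of 48 h (on this read-out lower numbers stand for stronger inhibition and higher numbers for weaker inhibition), compound 1 gives 20500 nM, the highest of the three numbers shown, though its gaps to the other two compounds both lie within the scatter. Compound 2 `COc1ccc(-c2nnc(SCCn3c([N+](=O)[O-])cnc3C)o2)cc1` carries a methoxy in place of hydrogen on an aromatic carbon, and in this assay compound 2 gives 10600 nM; that step is a 1.9-fold lower number from compound 1 to compound 2 (0.29 log units; within the scatter). Compound 3 `Cc1ncc([N+](=O)[O-])n1CCSc1nnc(-c2ccc([N+](=O)[O-])cc2)o1` carries a nitro at the same place, and in this assay compound 3 gives 12700 nM; that step is a 1.6-fold lower number from compound 1 to compound 3 (0.21 log units; within the scatter). Between those two, a 1.2-fold higher number from compound 2 to compound 3 (0.08 log units; within the scatter).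

Compound 4 `Cc1ncc([N+](=O)[O-])n1CCSc1nnc(-c2ccc(F)cc2)o1` differs from compound 1 by fluoro in place of hydrogen on an aromatic carbon. The two measured steps that bear on it are the methoxy and nitro replacements at this position, each of which moved the number only within the scatter, and in the same direction. A fluoro at this place is therefore expected to behave alike: a small step, if any, toward a lower number, but not one that would stand out from repeated measurement. In this assay compound 4 is expected to show a 1.4-fold lower number from compound 1 to compound 4 (0.14 log units; within the scatter), giving an estimated 15000 nM, with a plausible range from 7000 nM to 35000 nM.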

Compound 4, half-maximal inhibitory concentration: 8100 nM
Beside the measured number, compound 4's estimate is 1.9-fold (0.27 log units) above it, within the range that was stated.
By their numbers in this assay, from the lowest: compounds 4, 2, 3 and 1 (each within the scatter of the next, the first and the last beyond it).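

In this assay, among the compounds shown here, the change from phenyl to 4-fluorophenyl gives a 2.5-fold lower number from compound 1 to compound 4 (0.40 log units; beyond the scatter), and this is the first step at this place, on an aromatic carbon para to a large group, that lies beyond the scatter; neither the methoxy step nor the nitro step did so. The fluoro does not set compound 4 apart from the other two substituted compounds, however: the reading is a 1.6-fold lower number from compound 3 to compound 4 (0.20 log units; within the scatter) and a 1.3-fold lower number from compound 2 to compound 4 (0.12 log units; within the scatter), both within the scatter, so compounds 2, 3 and 4 cannot be ordered among themselves, and the result shows only that a single fluorine at this place can carry the number clear of the parent, by a modest margin. Nothing shown here accounts for why this one replacement, and neither of the other two, clears the scatter.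

On these data alone, whether the step belongs to fluoro alone or extends to other groups at this place stays open, since the series holds no chloro, amine or carboxylic acid there. Also open, as far as these compounds go, is whether a longer chain in place of the link within the shared core would leave the fluoro step intact.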